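This account rests on a few compounds, and the source may have more. Where it says the series, first, only, none or still open, it means among the compounds named here.

Compound 1 `CCC1CCN(c2cc(C(F)(F)F)ccc2CNC(=O)C(C)c2ccc(NS(C)(=O)=O)c(F)c2)CC1` gives 0.7 nM in an assay on CHO cells for antagonist activity at transient receptor potential cation channel subfamily V member 1 (Homo sapiens), read by FLIPR; a lower number here means a stronger inhibitor, a higher number a weaker inhibitor. Among the three compounds measured, compound 1 sits second highest: compound 2 `CC(C)CCOc1cc(C(F)(F)F)ccc1CNC(=O)C(C)c1ccc(NS(C)(=O)=O)c(F)c1` gives 0.5 nM, and compound 3 `CC(C)CCSc1cc(C(F)(F)F)ccc1CNC(=O)C(C)c1ccc(NS(C)(=O)=O)c(F)c1` gives 1.4 nM. Going by the values given here, the steps of a 1.4-fold lower number from compound 1 to compound 2 (0.15 log units; within the scatter) and a 2.0-fold higher number from compound 1 to compound 3 (0.30 log units; within the scatter) show that swapping the 4-ethylpiperidin-1-yl group for an isopentyl chain carried on oxygen or sulfur leaves the number little moved, while a 2.8-fold higher number from compound 2 to compound 3 (0.45 log units; beyond the scatter) is the only step beyond the scatter. Compound 4 `CCCCCc1cc(C(F)(F)F)ccc1CNC(=O)C(C)c1ccc(NS(C)(=O)=O)c(F)c1` takes the same kind of step: pentyl in place of 4-ethylpiperidin-1-yl on an aromatic carbon. The entering pentyl group has no ring and sits in the same place, so the change is expected to stay within or near the scatter, if anything toward a slightly higher number. Compound 4 is therefore estimated at 1 nM, with a range of 0.3 nM to 3 nM, which corresponds to an expected step of a 1.4-fold higher number from compound 1 to compound 4 (0.15 log units; within the scatter).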

Compound 4, inhibition constant: 0.4 nM
Compound 4: middle estimate off by 2.5-fold (0.40 log units), on the high side; measured number inside the range.
By their numbers in this assay, from the lowest: compounds 4, 2, 1 and 3 (each within the scatter of the next, the first and the last beyond it).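

In this assay a pentyl chain, with no ring and no hetero atom, serves at this position as well as the larger groups: a 1.8-fold lower number from compound 1 to compound 4 (0.24 log units; within the scatter) and a 1.3-fold lower number from compound 2 to compound 4 (0.10 log units; within the scatter) both stay within the scatter. Only a 3.5-fold lower number from compound 3 to compound 4 (0.54 log units; beyond the scatter) goes beyond it, although compound 3 and compound 1 remain within the scatter of each other. Nothing available explains these steps.

Open, as far as these compounds go, is whether a shorter propyl chain or a longer octyl chain holds the number this low. Also open, from the compounds shown here alone, is how a terminal amine or carboxylic acid on the pentyl chain would read.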